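The compounds below may be only part of what the source reports. "The series", "measured", "known", "first", "only" and "open" are said of these compounds alone.

Compound 1 `O=C(Cc1csc2nc(-c3ccc(Br)cc3)cn12)N/N=C/c1ccccc1O`: 20900 nM
Compound 2 `O=C(Cc1csc2nc(-c3ccc(Br)cc3)cn12)N/N=C/c1ccc(O)cc1`: 26300 nM

In a functional assay on SK-MEL-2 cells (Homo sapiens) for inhibition, read by sulforhodamine B assay, with a stated time of 48 h (a higher number here means a weaker inhibitor of growth, a lower number a stronger inhibitor of growth), compound 2 gives 26300 nM, and this cannot be told apart from compound 1 at 20900 nM. Compound 3 `COc1cccc(OC)c1/C=N/NC(=O)Cc1csc2nc(-c3ccc(Br)cc3)cn12` carries 2,6-dimethoxyphenyl in place of 4-hydroxyphenyl on a carbon with a double bond to nitrogen. Among the measured compounds shown here, the only measured step, a 1.3-fold higher number from compound 1 to compound 2 (0.10 log units; within the scatter), exchanged one hydroxyphenyl for another and stayed within the scatter. For the measured compounds named here, no measured compound carries methoxy groups, so this is weak guidance, and no step beyond the scatter is expected. The expected change is a 1.2-fold lower number from compound 2 to compound 3 (0.08 log units; within the scatter). Compound 3 is estimated at 22000 nM, within an expected range from 8000 nM to 55000 nM.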

Compound 3, concentration for 50% growth inhibition: 89100 nM
Beside the measured number, compound 3's estimate is 4.1-fold (0.61 log units) below it, outside the stated range (above it).
By their numbers in this assay, from the lowest: compounds 1 and 2 (each within the scatter of the next); then compound 3.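

This position is not indifferent to what sits on it. Swapping one hydroxyphenyl for the other changed little, but 2,6-dimethoxyphenyl weakens growth inhibition in this assay, with a 3.4-fold higher number from compound 2 to compound 3 (0.53 log units; beyond the scatter) and a 4.3-fold higher number from compound 1 to compound 3 (0.63 log units; beyond the scatter) as the two steps. No supporting measurement explains this loss.

Going by these compounds, it remains open whether both methoxy groups are needed for the loss, or whether one alone would produce it. Also untested here is how an amine or a carboxylic acid on this phenyl ring would compare.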